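This account rests on a few compounds, and the source may have more. Where it says the series, first, only, none or still open, it means among the compounds named here.

Measured so far:
- Compound 1, `CC(C)[C@@H]1CC[C@@H](C)C[C@@]12N(C)C(=O)[C@@H]1[C@H]3C(=O)NC(=O)[C@H]3ON12`: 35.6%
- Compound 2, `Cc1cccc(N2C(=O)[C@H]3[C@H](ON4[C@@H]3C(=O)N(C)[C@@]43C[C@H](C)CC[C@H]3C(C)C)C2=O)c1`: 39%

Both numbers come from a functional assay, read by spectrophotometry, with a stated time of 2 h, tested at 1 mg/mL; a lower number here means a weaker effect, a higher number a stronger effect of the compound at the concentration tested. Compound 1 and compound 2 differ only in that compound 2 carries a 3-methylphenyl in place of hydrogen on an amide-type nitrogen in a ring, and this step gave a number 3.4 percentage points higher from compound 1 to compound 2 (within the scatter). The two values therefore lie within the usual scatter of each other, and neither compound can be set above the other on the numbers shown; compound 2 is simply one of two compounds with closely similar read-outs.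

Compound 3, `CC(C)[C@@H]1CC[C@@H](C)C[C@@]12N(C)C(=O)[C@@H]1[C@H]3C(=O)N(c4ccc5ccccc5c4)C(=O)[C@H]3ON12`, has not yet been measured in this assay. It differs from compound 2 by naphthalen-2-yl in place of 3-methylphenyl on an amide-type nitrogen in a ring.

Within the data shown here, the only measured step that bears on this position is the one from compound 1 to compound 2, which stayed within the scatter. Among the measured compounds shown here, no step from one aromatic group to another at this nitrogen has been measured. On this basis no step beyond the scatter is expected, and the estimated step is no change at the digits printed from compound 2 to compound 3 (within the scatter). Compound 3 is therefore expected to give about 39% in this assay, within a range from 25% to 53%.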

Compound 3, a percentage reported as activity, at one concentration (the size of the read-out at that concentration, not a potency): 29.6%
Estimate against measurement, compound 3: 9.4 percentage points above; measured number inside the range.
By their numbers in this assay, from the lowest: compounds 3, 1 and 2 (each within the scatter of the next).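

Putting naphthalen-2-yl, with 2 six-membered aromatic rings, in place of 3-methylphenyl, with one, gave a number 9.4 percentage points lower from compound 2 to compound 3 (within the scatter) in this assay. Measured against the unsubstituted nitrogen, the same group gave a number 6 percentage points lower from compound 1 to compound 3 (within the scatter), so hydrogen, 3-methylphenyl and naphthalen-2-yl on this amide-type nitrogen cannot be told apart in this read-out, and even the larger aromatic group does not move it beyond the scatter. No measurement at hand offers an explanation for these small differences, or for the lack of any larger one.

As far as these compounds go, both aromatic groups here contain carbon only, so it remains open whether a pyridine ring, a benzyl group or a chain ending in a carboxylic acid on this nitrogen would shift the read-out beyond the scatter. All three compounds also keep the rest of the core unchanged and were read at one concentration, which leaves open both how other parts of the core contribute and how the compounds compare in potency.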